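Swapping the Methylphenyl Amide for a Pyridine Ring

This account rests on a few compounds, and the source may have more. Where it says the series, first, only, none or still open, it means among the compounds named here.

Inhibition in a functional assay on the whole organism (strain Swiss Albino) for inhibition, with Mus musculus as the target, in the writhing test, with a stated time of 1 h, at a dose of 100 mg/kg by the oral route (a lower number here means less inhibition, a higher number more inhibition at the dose given (going by the name of the read-out)), for the three measured compounds:
Compound 1, `COc1cc2c(cc1OC)C(CC(=O)Nc1ccccc1)CC2`: 42.8%
Compound 2, `COc1cc2c(cc1OC)C(CC(=O)Nc1cccc(Cl)c1)CC2`: 51.5%
Compound 3, `COc1cc2c(cc1OC)C(CC(=O)Nc1ccc(C)cc1)CC2`: 41.4%

All three share one core and differ only in the ring attached to the amide nitrogen. Compound 3 has the lowest of the three numbers, but compound 1 sits within the scatter of it: a number 1.4 percentage points lower from compound 1 to compound 3 (within the scatter). Going by the values given here, the only step that goes beyond the scatter is a number 10.1 percentage points lower from compound 2 to compound 3 (beyond the scatter), while a number 8.7 percentage points higher from compound 1 to compound 2 (within the scatter).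

Compound 4, `COc1cc2c(cc1OC)C(CC(=O)Nc1ccncc1)CC2`, differs from compound 3 in one place: pyridin-4-yl in place of 4-methylphenyl on an amide-type nitrogen. Among the compounds with values here, none of the measured steps places a nitrogen in the ring on the amide nitrogen, so no step bears directly on this change; the steps that exist stay small, within or just beyond the scatter. The change from compound 3 to compound 4 is therefore expected to be a number 0.6 percentage points higher from compound 3 to compound 4 (within the scatter), no step beyond the scatter. In this assay compound 4 is estimated at 42%, with a range from 30% to 55%.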

Compound 4, a percentage reported as inhibition, in the whole organism at one dose (the size of the read-out at that dose, not a potency): 60.1%
Compound 4: middle estimate off by 18.1 percentage points, on the low side; measured number above the stated range.
By their numbers in this assay, from the lowest: compounds 3, 1, 2 and 4 (each within the scatter of the next, the first and the last beyond it).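

In this assay the ring on the amide nitrogen proves able to move the number well beyond the scatter without any added substituent: pyridin-4-yl gives a number 18.7 percentage points higher from compound 3 to compound 4 (beyond the scatter) and a number 17.3 percentage points higher from compound 1 to compound 4 (beyond the scatter) in the two comparisons with carbon-only rings. Against the 3-chlorophenyl ring the same change gives a number 8.6 percentage points higher from compound 2 to compound 4 (within the scatter), so these two rings cannot be told apart in this test. Nothing available here explains why a ring nitrogen at this place goes with a higher number.

Going by these compounds, what pyridin-3-yl or pyridin-2-yl would give on the same amide nitrogen remains open, so the data cannot say whether the place of the ring nitrogen matters. Also open, on these data alone, is whether a saturated piperidin-4-yl ring would keep the number seen with pyridin-4-yl.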